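Swapping a phenyl for a butyl chain at the urea end

The source may hold more compounds than are shown below. What is called first, only, known or untested is meant among the compounds shown, and "the series" means these compounds.

Measured so far in a functional assay on HEK293T cells for agonist activity at histamine H2 receptor (Homo sapiens), read by beta-arrestin recruitment; on this read-out higher numbers stand for an effect only at larger amounts of compound and lower numbers for an effect already at smaller amounts:
- compound 1 `Cc1nc(N)sc1CCCN/C(N)=N/C(=O)NC(c1ccccc1)c1ccccc1` gives 331 nM
- compound 2 `CCCCCCNC(=O)/N=C(\N)NCCCc1sc(N)nc1C` gives 85.1 nM
- compound 3 `Cc1nc(N)sc1CCCN/C(N)=N/C(=O)NCc1ccccc1` gives 100 nM

Compound 3 stands second highest of these three numbers: its nearest neighbour is compound 2, within the scatter, while compound 1 lies furthest away, with a 3.3-fold lower number from compound 1 to compound 3 (0.52 log units; beyond the scatter). Compound 4 `CCCCCNC(=O)/N=C(\N)NCCCc1sc(N)nc1C` differs from compound 3 by butyl in place of phenyl on a saturated chain carbon bound to an amide-type nitrogen. For the measured compounds named here, the one measured step that bears on this is a 1.2-fold higher number from compound 2 to compound 3 (0.07 log units; within the scatter), where a phenyl replaced a pentyl at this very position with no change beyond the scatter. Going back from phenyl to a chain one carbon shorter is therefore expected to give a 1.1-fold lower number from compound 3 to compound 4 (0.02 log units; within the scatter), no real step in this assay. Compound 4 is estimated at 95 nM, with a range from 45 nM to 200 nM.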

Compound 4, half-maximal effective concentration: 178 nM
For compound 4 the middle estimate is 1.9-fold (0.27 log units) below the measured one; the range from low to high includes it.
By their numbers in this assay, from the lowest: compounds 2, 3, 4 and 1 (each within the scatter of the next, the first and the last beyond it).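

In this assay, butyl in place of phenyl gives a 1.8-fold higher number from compound 3 to compound 4 (0.25 log units; within the scatter) and so the aromatic ring and the open chain cannot be told apart at this position. Chain length does register, if only slightly: hydrogen in place of methyl, five bonds along the chain from the amide-type nitrogen, gives a 2.1-fold higher number from compound 2 to compound 4 (0.32 log units; beyond the scatter) as a modest step. No measurement here explains either result.

Still open, on these data alone, is how a longer chain such as octyl would behave. So is the effect of an amine or a carboxylic acid on the chain.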